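The source may hold more compounds than are shown below. What is called first, only, known or untested is meant among the compounds shown, and "the series" means these compounds.

Working notes on the series. In a functional assay on A549 cells (Homo sapiens) for inhibition, with a stated time of 48 h, tested at 50 uM (a higher number here means more inhibition of growth at the concentration tested, a lower number less inhibition of growth), compound 1 `C=C[C@@](C)(/C=C/c1ccc(OC(=O)CCCC)cc1)CCC=C(C)C` gives 38%, and compound 2 `COc1ccccc1/C=C/[C@@](C)(/C=C/c1ccc(O)cc1)CCC=C(C)C` gives 10%. Compound 2 is the lower of the two measured compounds, and its gap to compound 1 lies beyond the scatter. Compound 3 `COc1ccc(/C=C/[C@@](C)(/C=C/c2ccc(O)cc2)CCC=C(C)C)cc1` is still unmeasured. Its change from compound 2 is 4-methoxyphenyl in place of 2-methoxyphenyl on a double-bonded chain carbon bound to a double-bonded chain carbon, with 4-methoxyphenyl in place of 2-methoxyphenyl on a double-bonded chain carbon bound to a double-bonded chain carbon. Among the compounds with values here, no measured pair shows the effect of this change, so the expectation rests on compound 2 at 10% alone. A small upward move in this assay, probably within the scatter, is expected, and the estimated step is a number 5 percentage points higher from compound 2 to compound 3 (within the scatter). In this assay the expected value for compound 3 is 15%, with an estimated range of 3% to 35%.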

Compound 3, percent growth inhibition at one concentration: 40%
Estimate against measurement, compound 3: 25 percentage points below; the measured number lies above the stated range.
By their numbers in this assay, from the lowest: compound 2; then compounds 1 and 3 (each within the scatter of the next).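

In this assay, 4-methoxyphenyl in place of 2-methoxyphenyl on a double-bonded chain carbon bound to a double-bonded chain carbon gives a number 30 percentage points higher from compound 2 to compound 3 (beyond the scatter) with no atom gained or lost, the two groups being the same atoms joined differently. This place on the chain is therefore sensitive to how the methoxyphenyl group is arranged, something compound 1 and compound 2 could not show on their own.

From the compounds shown here alone, whether the 4-methoxy group itself matters stays open: an unsubstituted phenyl, a 4-hydroxyphenyl or a 4-chlorophenyl at the same place would help settle that. Also open, going by these compounds, is whether the change keeps its size on a core carrying an ester in place of the hydroxyl. Nothing measured here bears on the reason for this step.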